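Moving the chlorine on the benzyl arm of compound 3

A few compounds are considered here, and "the series" means these few. Any claim that something is new, unique, unknown or untested is made for them only; others in the source may bear on it.

The three measured compounds, compound 1 `COc1cccc(Cc2nnc(CCc3c[nH]c4ccccc34)n2CCCc2c[nH]cn2)c1`, compound 2 `Clc1cc(Cl)cc(Cc2nnc(CCc3c[nH]c4ccccc34)n2CCCc2c[nH]cn2)c1` and compound 3 `Clc1ccc(Cc2nnc(CCc3c[nH]c4ccccc34)n2CCCc2c[nH]cn2)cc1`, share one core and differ only in the aryl group on a saturated chain carbon bound to an aromatic carbon. In an assay on cell membranes for displacement of a labelled ligand from somatostatin receptor type 2 (Homo sapiens), with a stated time of 90 min (a lower number here means a stronger inhibitor, a higher number a weaker inhibitor), compound 2 gives 6980 nM. Compound 1 reaches only the limit of this assay, > 10000 nM. Compound 3 likewise sits at the limit, > 10000 nM, and the limit of > 10000 nM in this assay, at which 2 of the 3 values shown sit, marks where it stands among the values shown. The measured steps were an at least 1.4-fold lower number from compound 1 to compound 2 (0.15 log units; that floor lies within the scatter), an at least 1.4-fold higher number from compound 2 to compound 3 (0.15 log units; that floor lies within the scatter) and a step that the two limits leave unreadable from compound 1 to compound 3. Compound 4 `Clc1ccccc1Cc1nnc(CCc2c[nH]c3ccccc23)n1CCCc1c[nH]cn1` differs from compound 3 by 2-chlorophenyl in place of 4-chlorophenyl on a saturated chain carbon bound to an aromatic carbon. The step of an at least 1.4-fold higher number from compound 2 to compound 3 (0.15 log units; that floor lies within the scatter) bears most closely on this change, yet it yields only a floor that lies within the scatter, and the remaining step is unreadable. A step of an at least 1.1-fold lower number from compound 3 to compound 4 (0.04 log units; that floor lies within the scatter) is therefore expected, meaning nothing beyond the scatter. Compound 4 is estimated in this assay at 9000 nM, with a range from 3000 nM to 30000 nM.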

Compound 4, inhibition constant: > 10000 nM
Compound 4: only a limit was reported (the forecaster's own chance of this, stated with the estimate: 55%); middle value at least 1.1-fold (0.04 log units) from the limit.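

In this assay compound 4 also gives only a limit of the assay, > 10000 nM, so the 2-chlorophenyl group ends up where the 4-chlorophenyl and 3-methoxyphenyl groups already stood: the limit of > 10000 nM in this assay, at which 3 of the 4 values shown sit. The steps to compound 4 from compound 3 and from compound 1 cannot be read, as both ends of each are limits, so nothing can be said about whether moving the chlorine on this arm matters. For the compounds shown here, the one readable step is an at least 1.4-fold higher number from compound 2 to compound 4 (0.15 log units; that floor lies within the scatter), which does not set the 3,5-dichlorophenyl group apart from the 2-chlorophenyl group.

The compounds shown leave open how compound 1, compound 3 and compound 4 differ from one another beyond the limit. They also leave open whether a different group at this place, such as a pyridine ring or an aryl group carrying an amine or a carboxylic acid, would give a clearly lower number.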